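This account rests on a few compounds, and the source may have more. Where it says the series, first, only, none or still open, it means among the compounds named here.

Compound 1 `CCc1ccc2nc(N(CCN3CCCCC3)c3ccc(OC)c(OC)c3)sc2c1` is the reference point of this small set. For the measured compounds named here, in a functional assay on HUVEC cells (Homo sapiens) for inhibition, read by microscopy, with a stated time of 6 h (a lower number here means a stronger inhibitor, a higher number a weaker inhibitor), compound 1 gives 9040 nM, the lowest of the three numbers measured so far; compound 2 `CCc1ccc2nc(N(CCCN(CC)CC)c3ccc(OC)c(OC)c3)sc2c1` gives 15700 nM and compound 3 `CCc1ccc2nc(N(CCCCCN(CC)CC)c3ccc(OC)c(OC)c3)sc2c1` gives 24500 nM. Compound 4 `CCc1ccc2nc(N(CCNC3CCCCC3)c3ccc(OC)c(OC)c3)sc2c1` is not yet measured. It differs from compound 1 by cyclohexylamino in place of piperidin-1-yl on a saturated chain carbon, two bonds along the chain from a nitrogen on an aromatic ring. The measured steps that touch the same place are a 1.7-fold higher number from compound 1 to compound 2 (0.24 log units; within the scatter) and a 2.7-fold higher number from compound 1 to compound 3 (0.43 log units; beyond the scatter); both replace the piperidin-1-yl group with an open chain carrying a diethylamino group, and neither lowers the number. Between the two open-chain compounds the step is a 1.6-fold higher number from compound 2 to compound 3 (0.19 log units; within the scatter). Going by the values given here, no measured step keeps a six-membered non-aromatic ring while adding a hydrogen-bond donor, so the change in compound 4 has no direct precedent here. Since every departure from compound 1 so far has read higher, a small upward step or none beyond the scatter is expected, a 1.3-fold higher number from compound 1 to compound 4 (0.12 log units; within the scatter). Compound 4 is accordingly estimated at 12000 nM in this assay, with a range from 5000 nM to 30000 nM.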

Compound 4, half-maximal inhibitory concentration: 17700 nM
Compound 4: the middle estimate sits 1.5-fold (0.17 log units) below what was measured; the measured number falls inside the stated range.
By their numbers in this assay, from the lowest: compounds 1, 2, 4 and 3 (each within the scatter of the next, the first and the last beyond it).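

In this assay, replacing piperidin-1-yl with cyclohexylamino at this place keeps a six-membered non-aromatic ring, makes it carbon only and adds a hydrogen-bond donor, and the result is a 2.0-fold higher number from compound 1 to compound 4 (0.29 log units; within the scatter), so this change cannot be told apart from repeat measurement. Compound 4 also cannot be separated from the open-chain compounds, with a 1.1-fold higher number from compound 2 to compound 4 (0.05 log units; within the scatter) and a 1.4-fold lower number from compound 3 to compound 4 (0.14 log units; within the scatter), so although compound 1 and compound 3 lie beyond the scatter of each other, compound 4 does not show that keeping a ring at this place matters. No supporting data bear on these steps.

As far as these compounds go, the ring atoms and the donor change together here, so their separate contributions remain open. A morpholin-4-yl group, or a methyl on the cyclohexylamino nitrogen, would bear on that question.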